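Swapping Phenyl for Naphthalen-1-yl: Expected Growth Inhibition

The source may hold more compounds than are shown below. What is called first, only, known or untested is meant among the compounds shown, and "the series" means these compounds.

Compound 1 `COc1ccccc1/C=C/C(=O)/C=C/c1ccc(OCc2cn(CCCCCOc3cc(=O)oc4ccccc34)nn2)c(OC)c1`: "not active" (no number reported)
Compound 2 `COc1cc(/C=C/C(=O)/C=C/c2ccccc2)ccc1OCc1cn(CCCCCOc2cc(=O)oc3ccccc23)nn1`: "not active" (no number reported)
Compound 3 `COc1ccc(/C=C/C(=O)/C=C/c2ccc(OCc3cn(CCCOc4cc(=O)oc5ccccc45)nn3)c(OC)c2)cc1OC`: 9%

Of the compounds shown here, three have been tested in a functional assay on PC-3 cells (Homo sapiens) for inhibition, read by sulforhodamine B assay, with a stated time of 48 h, tested at 50 uM; a lower number here means less inhibition of growth, a higher number more inhibition of growth at the concentration tested. Compound 1 gives "not active" (no number reported). Compound 2 likewise gives "not active" (no number reported), so no single number stands for it; one further compound also lacks a number. Compound 3 is the only one with a figure, giving 9% in this assay, which is small. Going by the values given here, no pair of these three differs in one place only, so no step between measured compounds can be drawn.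

Compound 4 `COc1cc(/C=C/C(=O)/C=C/c2cccc3ccccc23)ccc1OCc1cn(CCCCCOc2cc(=O)oc3ccccc23)nn1` has not yet been tested. It differs from compound 2 in a single place, described as naphthalen-1-yl in place of phenyl on a double-bonded chain carbon bound to a double-bonded chain carbon.

Among the compounds with values here, with compound 2 reported without a number, and the only numbered compound, compound 3, showing weak inhibition, the expected step in this assay from compound 2 to compound 4 cannot be sized from the data; nothing beyond the usual scatter is anticipated in either direction.

Compound 4 is therefore expected to show weak inhibition, estimated at 10%, with a likely range from 0% to 30%, and a sizeable chance that it is again reported without a number.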

Compound 4, percent growth inhibition at one concentration: "not active" (no number reported)
No number was reported for compound 4, and the estimate cannot be compared.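

In this assay, going by these compounds alone, compound 2 gives "not active" (no number reported) and compound 4 gives "not active" (no number reported) so no step between these two compounds can be read. No other evidence shown here bears on this result. The compounds shown leave open whether naphthalen-1-yl in place of phenyl makes any difference to growth inhibition.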